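This account rests on a few compounds, and the source may have more. Where it says the series, first, only, none or still open, it means among the compounds named here.

Compound 1 `O=C(NCc1ccccc1)N(Cc1ccccn1)n1cnnc1` was examined in a functional assay on MCF7 cells (Homo sapiens) for cytotoxicity, read by MTT assay, with a stated time of 48 h; on this read-out lower numbers stand for stronger inhibition and higher numbers for weaker inhibition. In this assay compound 1 gives only the limit > 50000 nM, so no number is known for it. Compound 1 thus stands at the limit of > 50000 nM in this assay, at which 2 of the 3 values shown sit. Compound 2 `CCc1ccc(NC(=O)N(Cc2ccc(OC)c(OC)c2)n2cnnc2)cc1` likewise returns only the limit > 50000 nM in this assay. Among the measured compounds shown here, compound 3 `N#Cc1ccc(CN(C(=O)Nc2cc(C(F)(F)F)cc(C(F)(F)F)c2)n2cnnc2)cc1` is the one compound with a measured value, 7220 nM in this assay. Compound 4 `CC1CCC(NC(=O)N(Cc2ccccn2)n2cnnc2)CC1` differs from compound 1 by 4-methylcyclohexyl in place of benzyl on an amide-type nitrogen. No measured step of this kind exists among the three compounds, so nothing shown speaks for a gain. The step is expected to be a number no higher from compound 1 to compound 4 (the limit leaves the size open), none beyond the scatter. Compound 4 is therefore expected to give about 50000 nM in this assay, within 15000 nM to 200000 nM.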

Compound 4, half-maximal inhibitory concentration: 34000 nM
The estimate for compound 4 lay 1.5-fold (0.17 log units) above the measured number, and the stated range covers the measured number.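

In this assay, 4-methylcyclohexyl in place of benzyl on an amide-type nitrogen gives an at least 1.4-fold lower number from compound 1 to compound 4 (0.16 log units; that floor lies within the scatter), so this change shows no gain beyond the scatter. It does show that a six-membered aromatic ring of carbon is not required at this position for a number to be read, since compound 4 gives a measured value. Compound 1 remains only a limit, so the true size of the step stays unknown: the limit of > 50000 nM in this assay, at which 2 of the 4 values shown sit.

Going by these compounds, it remains open whether plain cyclohexyl, an amine or a longer alkyl chain at this position would move the number beyond the scatter.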